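A Methyl Added to an Inactive Pair

The source may hold more compounds than are shown below. What is called first, only, known or untested is meant among the compounds shown, and "the series" means these compounds.

Compound 1, `COc1cc(-c2nnc(SCc3ccccc3Cl)n2N2C(=O)c3ccccc3C2=O)cc(OC)c1OC`, tested in a functional assay on MKN-45 cells (Homo sapiens) for cytotoxicity, read by MTT assay, with a stated time of 48 h; a lower number here means a stronger inhibitor, a higher number a weaker inhibitor. In this assay compound 1 gives only a limit, > 200000 nM.
Compound 2, `COc1cc(-c2nnc(SCC(=O)c3ccccc3)n2N2C(=O)c3ccccc3C2=O)cc(OC)c1OC`, tested in this assay. In this assay compound 2 gives only a limit, > 200000 nM.

Compound 2 stands at the limit of this assay, and the other value also sits there: the limit of > 200000 nM in this assay, at which 2 of the 2 values shown sit. Going by the values given here, the one measured step, a step that the two limits leave unreadable from compound 1 to compound 2, is therefore unreadable, and nothing measured says how a change on the benzoyl ring moves potency. Compound 3, `COc1cc(-c2nnc(SCC(=O)c3ccccc3C)n2N2C(=O)c3ccccc3C2=O)cc(OC)c1OC`, differs from compound 2 by methyl in place of hydrogen on an aromatic carbon. Among the compounds with values here, no measured step bears readably on this change, so no step beyond the scatter can be expected in this assay for compound 3, and most likely only a limit again. The expected step is a step that the limit leaves unreadable from compound 2 to compound 3. Compound 3 is estimated at 250000 nM, in the range 100000 nM to 700000 nM.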

Compound 3, half-maximal inhibitory concentration: > 200000 nM
Compound 3: no number, only a limit; the forecaster's own chance of this, stated with the estimate: 85%; the middle value is on the limit's open side.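

In this assay, going by these compounds alone, compound 3 gives > 200000 nM as a limit and not a number, so no step to it from compound 1 or compound 2 can be read: the limit of > 200000 nM in this assay, at which 3 of the 3 values shown sit. As far as these compounds go, whether any change on the shared core moves potency in this assay stays open.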